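This account rests on a few compounds, and the source may have more. Where it says the series, first, only, none or still open, it means among the compounds named here.

In an ADME assay on MT2 cells (Homo sapiens) for cytotoxicity, read by XTT assay, with a stated time of 4 days (on this read-out higher numbers stand for lower toxicity in this test and lower numbers for higher toxicity in this test), compound 1 (`Cc1ccc(NC(=O)C(=O)NC(c2nc(C)c(CCO)s2)C2CCCCN2)c(F)c1`) gives > 78800 nM, which is a limit and not a number. Compound 2 (`Cc1ccc(NC(=O)C(=O)NC(c2nc(C)c(CO)s2)C2CCCCN2)c(F)c1`) gives > 109000 nM, also a limit. Compound 3 (`Cc1nc(C(NC(=O)C(=O)Nc2ccc(F)cc2F)C2CCCCN2)sc1CO`) gives > 110000 nM, again a limit. Compound 1 therefore stands among three results that are all limits, and they cannot be ranked against one another.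

Compound 4 (`Cc1nc(C(NC(=O)C(=O)Nc2ccc(F)cc2)C2CCCCN2)sc1CCO`) keeps the core of compound 1 and differs only on the amide-type nitrogen, where 4-fluorophenyl takes the place of 2-fluoro-4-methylphenyl: 4-fluorophenyl in place of 2-fluoro-4-methylphenyl on an amide-type nitrogen. For the measured compounds named here, two measured steps bear on this change. The swap of hydroxy for hydroxymethyl gave a step that the two limits leave unreadable from compound 1 to compound 2, and the swap of fluoro for methyl on an aromatic carbon gave a step that the two limits leave unreadable from compound 2 to compound 3. The second lies closer to the present change, but neither has a readable size, and neither produced a measured number. No step beyond the scatter is therefore expected, and the estimate is a step that the limit leaves unreadable from compound 1 to compound 4. Compound 4 is expected at 90000 nM, with an estimated range of 45000 nM to 130000 nM, and will most likely be reported as a limit again.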

Compound 4, half-maximal cytotoxic concentration: 109000 nM
For compound 4 the middle estimate is 1.2-fold (0.08 log units) below the measured one; low and high end bracket the measured number.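

No new step can be read: compound 4 gives a number, whereas compound 1 has only a limit, and the change between them has no readable size. The compounds shown leave open whether 4-fluorophenyl in place of 2-fluoro-4-methylphenyl changes the result in this assay at all.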